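The source may hold more compounds than are shown below. What is called first, only, known or untested is meant among the compounds shown, and "the series" means these compounds.

Measured in an ADME assay on MT4 cells (Homo sapiens) for activation, read by MTT assay; on this read-out lower numbers stand for higher toxicity in this test and higher numbers for lower toxicity in this test:
- compound 1 `CCCSc1nc(Cc2c(F)cccc2Cl)c(C)c(=O)[nH]1`: > 76000 nM
- compound 2 `CCCCSc1nc(Cc2c(F)cccc2Cl)c(C)c(=O)[nH]1`: > 73000 nM

Both entries are limits of the assay, not numbers, so compound 1 has no exact position on the scale. Compound 3 `CCCSc1nc(C(C)c2c(F)cccc2Cl)c(C)c(=O)[nH]1` differs from compound 1 by one change, (methyl in place of hydrogen on a saturated chain carbon bound to two aromatic carbons), a methyl in place of hydrogen on a saturated chain carbon bound to two aromatic carbons. Within the data shown here, the only measured step, a step that the two limits leave unreadable from compound 1 to compound 2, also adds a methyl, but three bonds along the chain from a sulfur, and gives no usable size. No step beyond the usual scatter is therefore expected, and the estimated change is an at least 1.0-fold lower number from compound 1 to compound 3 (0.03 log units; that floor lies within the scatter). Compound 3 is expected near 70000 nM, with an estimated range of 25000 nM to 150000 nM.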

Compound 3, half-maximal cytotoxic concentration: > 1500 nM
Compound 3: no number, only a limit; the forecaster's own chance of this, stated with the estimate: 65%; the middle value does not contradict the limit.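

Among these compounds, compound 1 and compound 3 are both recorded only as limits, so no step between them can be read. The compounds shown leave open whether the added methyl changes the result in this assay at all.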